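A few compounds are considered here, and "the series" means these few. Any claim that something is new, unique, unknown or untested is made for them only; others in the source may bear on it.

Compound 1, `Cc1ccc(S(=O)(=O)N[C@H]2CCN(CCCOc3ccc(C(=O)C4CC4)cc3)C2)cc1`, gives 380 nM in an assay on isolated protein for binding affinity to histamine H2 receptor (Homo sapiens) (a lower number here means a stronger inhibitor, a higher number a weaker inhibitor), the lowest of the three numbers measured. Compound 2, `COc1ccc(S(=O)(=O)N[C@H]2CCN(CCCOc3ccc(C(=O)C4CC4)cc3)C2)cc1`, gives 1000 nM, and compound 3, `O=C(c1ccc(OCCCN2CC[C@H](NS(=O)(=O)c3ccccc3)C2)cc1)C1CC1`, gives 1200 nM, so the methyl group of compound 1 goes with the strongest binding here: a 2.6-fold higher number from compound 1 to compound 2 (0.42 log units; beyond the scatter) and a 3.2-fold higher number from compound 1 to compound 3 (0.50 log units; beyond the scatter). Compound 4, `Cc1ccccc1S(=O)(=O)N[C@H]1CCN(CCCOc2ccc(C(=O)C3CC3)cc2)C1`, keeps that methyl but changes its position: 2-methylphenyl in place of 4-methylphenyl on a sulfonyl sulfur. Both measured steps altered the group rather than moving it, so they bear only loosely on this change, and each shifted the number modestly upward. A small to modest rise is therefore expected, giving a 1.8-fold higher number from compound 1 to compound 4 (0.27 log units; within the scatter). Compound 4 is estimated at 700 nM in this assay, within a range of 300 nM to 1800 nM.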

Compound 4, inhibition constant: 2200 nM
Beside the measured number, compound 4's estimate is 3.1-fold (0.50 log units) below it; the whole stated range lies below it.
By their numbers in this assay, from the lowest: compound 1; then compounds 2, 3 and 4 (each within the scatter of the next, the first and the last beyond it).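

The position of the methyl matters, not just its presence: with the same atoms joined differently, 2-methylphenyl in place of 4-methylphenyl gives a 5.8-fold higher number from compound 1 to compound 4 (0.76 log units; beyond the scatter) in this assay. The 2-methylphenyl group shows none of the gain seen with 4-methylphenyl, giving a 1.8-fold higher number from compound 3 to compound 4 (0.26 log units; within the scatter) against the plain phenyl group, and it also gives a 2.2-fold higher number from compound 2 to compound 4 (0.34 log units; beyond the scatter). No supporting measurement explains this difference. From the compounds shown here alone, it remains open whether ethyl in place of the methyl of 4-methylphenyl, or an amine on that aromatic ring, would give a lower number.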